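A few compounds are considered here, and "the series" means these few. Any claim that something is new, unique, unknown or untested is made for them only; others in the source may bear on it.

Working notes on the ester series in an ADME assay on a cell-free system (plasma, Homo sapiens) for metabolic stability, read by LC-MS; a higher number here means that the compound lasts longer, a lower number that the compound disappears faster. Compound 2 `NCc1ccc(C(=O)Nc2ccncc2)cc1-c1cccc(C(=O)OCc2ccccc2)c1` gives 1.07 h, the higher of the two numerical readings in hand. Compound 1 `CCCCOC(=O)c1cccc(-c2cc(C(=O)Nc3ccncc3)ccc2CN)c1` gives 0.367 h. Within the data shown here, compound 3 `NCc1ccc(C(=O)Nc2ccncc2F)cc1-c1cccc(C(=O)O)c1` gives > 2 h, which is a limit of the assay and not a number, and it is the only compound at the limit of > 2 h in this assay, at which 1 of the 3 values shown sits.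

Next in line is compound 4 `CCOC(=O)c1cccc(-c2cc(C(=O)Nc3ccncc3)ccc2CN)c1`, whose change from compound 2 is methyl in place of phenyl on a saturated chain carbon bound to an oxygen next to a carbonyl group. Put briefly, benzyloxycarbonyl becomes ethoxycarbonyl.

Among the measured compounds shown here, only one measured step bears on this place: a 2.9-fold higher number from compound 1 to compound 2 (0.46 log units; beyond the scatter). That step is modest but beyond the scatter, and it brought in the same phenyl that compound 4 gives up. Taking phenyl out again therefore points to a lower number in this assay. For the measured compounds named here, the size of that earlier step is the only guide, and methyl is not the propyl of that comparison, so a somewhat smaller move is expected.

The estimated change is a 1.8-fold lower number from compound 2 to compound 4 (0.25 log units; within the scatter). The expected value for compound 4 is 0.6 h, with an estimated range from 0.25 h to 1.4 h.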

Compound 4, half-life: 0.683 h
Estimate against measurement, compound 4: 1.1-fold (0.06 log units) below; the range from low to high includes it.
By their numbers in this assay, from the lowest: compounds 1, 4 and 2 (each within the scatter of the next, the first and the last beyond it). At a limit, above all of these: compound 3.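

In this assay the change from benzyloxycarbonyl to ethoxycarbonyl gives a 1.6-fold lower number from compound 2 to compound 4 (0.19 log units; within the scatter) and so stays inside the scatter, which shows that phenyl on this saturated chain carbon is not needed for a reading of this size. The other new step, a 1.9-fold higher number from compound 1 to compound 4 (0.27 log units; within the scatter) for hydrogen in place of ethyl on a saturated chain carbon, two bonds along the chain from an oxygen next to a carbonyl group, is also within the scatter, so compound 4 cannot be told apart from either of the other two esters. Among these compounds, only the outer pair separates, with a 2.9-fold higher number from compound 1 to compound 2 (0.46 log units; beyond the scatter) as the sole step beyond the scatter, and that step can no longer be read as a plain phenyl effect, since compound 4 carries no phenyl and is not separated from compound 2.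

As far as these compounds go, whether a branched chain such as isopropyl, or an amide in place of the ester, would move the half-life beyond the scatter stays open. Nothing at hand gives a measured property that accounts for these readings.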